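The source may report more compounds than this note shows. Statements on the series, on what has been measured and on what is new or still open speak of the compounds shown alone.

Compound 1 `Cc1ccc(Oc2c(/C=N/OCc3snnc3C)c(C)nn2C)cc1` gives > 50000 nM in a functional assay on Huh-7 cells (Homo sapiens) for inhibition, read by MTT assay, with a stated time of 48 h; on this read-out lower numbers stand for stronger inhibition and higher numbers for weaker inhibition.
Compound 2 `CCc1nnsc1CO/N=C/c1c(C)nn(C)c1Oc1ccc(C)cc1` gives > 50000 nM in this assay.
Compound 3 `CCc1nnsc1CO/N=C/c1c(C)nn(C)c1Cl` gives > 50000 nM in this assay.

Each of these three values is a limit of the assay rather than a number. For compound 1 the value > 50000 nM is such a limit. For compound 2 the value > 50000 nM is likewise a limit. For compound 3 the value > 50000 nM is again a limit, so the limit of > 50000 nM in this assay, at which 3 of the 3 values shown sit, describes all three.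

The change between the measured pair is methyl in place of hydrogen on a saturated chain carbon bound to an aromatic carbon; it gave a step that the two limits leave unreadable from compound 1 to compound 2. The second measured step, a step that the two limits leave unreadable from compound 2 to compound 3, is equally unreadable from two limits. The difference between the core of compound 1 and the core of compound 3 is not broken down here.

Compound 4 `CCCc1nnsc1CO/N=C/c1c(C)nn(C)c1Cl` has not been measured. It carries methyl in place of hydrogen on a saturated chain carbon, two bonds along the chain from an aromatic carbon, the same kind of change as in the measured pair, but the place differs: there the carbon is bound to an aromatic carbon, here it lies two bonds along the chain from an aromatic carbon. Since every shown value sits at the limit, the expected step that the limit leaves unreadable from compound 3 to compound 4 rests on no readable size. Compound 4 is expected to give about 90000 nM in this assay, most likely again only a limit.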

Compound 4, half-maximal inhibitory concentration: > 50000 nM
Compound 4: no number, only a limit; the forecaster's own chance of this, stated with the estimate: 85%; the middle value does not contradict the limit.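

Compound 4 gives > 50000 nM in this assay, which is a limit and not a number. No size can be read for the step from compound 3 to compound 4, because both values are limits: the limit of > 50000 nM in this assay, at which 4 of the 4 values shown sit.

The compounds shown leave open what effect, if any, these changes have on inhibition in this assay, since none gives a readable number.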